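The compounds below may be only part of what the source reports. "The series", "measured", "known", "first", "only" and "open" are said of these compounds alone.

For the measured compounds named here, compound 2 `COc1ccc(-c2cc(C)c(N3CCN(c4ncccn4)CC3)nn2)cc1` is the one compound here that gives a number in a functional assay on BV-2 cells (Mus musculus) for inhibition, read by ELISA, with a stated time of 16 h; on this read-out lower numbers stand for stronger inhibition and higher numbers for weaker inhibition: compound 2 gives 5200 nM. Going by the values given here, the only other value shown is a limit rather than a number. In this assay compound 1 `Cc1cc(Cl)nnc1N1CCN(c2ncccn2)CC1` gives > 100000 nM, which is a limit of the assay (the limit of > 100000 nM in this assay, at which 1 of the 2 values shown sits). Among the compounds with values here, the single measured step, an at least 19-fold lower number from compound 1 to compound 2 (1.28 log units; beyond the scatter), is the only guide available, and it shows that placing an aromatic ring on that aromatic carbon, in place of chloro, moves the number by a large margin. Compound 3 `Cc1cc(-c2ccsc2)nnc1N1CCN(c2ncccn2)CC1` differs from compound 2 in one place: thiophen-3-yl in place of 4-methoxyphenyl on an aromatic carbon. Since compound 3 keeps an aromatic ring on the same aromatic carbon, the change is smaller in kind than the measured step, and a step of that size is not expected. A modest weakening, or no step beyond the scatter, is the expectation, and it is estimated as a 1.7-fold higher number from compound 2 to compound 3 (0.24 log units; within the scatter). In this assay compound 3 is therefore expected to give about 9000 nM, within an estimated range from 2500 nM to 35000 nM.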

Compound 3, half-maximal inhibitory concentration: 2400 nM
Estimate against measurement, compound 3: 3.8-fold (0.57 log units) above; measured number below the stated range.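

In this assay, the 4-methoxyphenyl group proves not to be required at this position, which is para to a large group: thiophen-3-yl, with 5 heavy atoms in place of 8, gives a 2.2-fold lower number from compound 2 to compound 3 (0.34 log units; beyond the scatter). A second aromatic ring, of a different size and carrying sulfur, therefore also outperforms chloro on this aromatic carbon, with an at least 41-fold lower number from compound 1 to compound 3 (1.61 log units; beyond the scatter), so the gain seen earlier is not peculiar to 4-methoxyphenyl. Compound 1 gives only a limit of the assay, and the true size of both steps away from chloro stays unknown because of it: the limit of > 100000 nM in this assay, at which 1 of the 3 values shown sits.

The change from compound 2 to compound 3 alters the ring size, the ring atoms and the methoxy group all at once, so the compounds shown cannot say which of these accounts for the modest step. They also leave open how this position would respond to a plain phenyl, a pyridine, a thiophene joined through a different ring carbon, or a non-aromatic group such as morpholine or a short alkyl chain.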